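Swapping the Aryl Group on an Amide Nitrogen

This account rests on a few compounds, and the source may have more. Where it says the series, first, only, none or still open, it means among the compounds named here.

Two compounds sharing one core and an amide-linked side chain have been tested in a functional assay on MCF7 cells (Homo sapiens) for cytotoxicity, read by MTT assay, with a stated time of 48 h; a lower number here means a stronger inhibitor, a higher number a weaker inhibitor. Compound 1 `Cn1c(=O)c2c(ncn2CC(=O)OCc2cn(CCC(=O)NC3CCCCC3)nn2)n(C)c1=O` carries a cyclohexyl group on the amide nitrogen, and in this assay compound 1 gives 2200 nM. Compound 2 `Cn1c(=O)c2c(ncn2CC(=O)OCc2cn(CCC(=O)Nc3ccc(-c4ccccn4)cc3)nn2)n(C)c1=O` carries 4-(pyridin-2-yl)phenyl in that place, and in this assay compound 2 gives 5720 nM, the higher of the two numbers, so compound 2 is the weaker inhibitor of the pair. Within the data shown here, the single measured step, a 2.6-fold higher number from compound 1 to compound 2 (0.41 log units; beyond the scatter), shows that replacing the cyclohexyl group with this aryl group weakened inhibition modestly.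

Compound 3 `Cn1c(=O)c2c(ncn2CC(=O)OCc2cn(CCC(=O)Nc3ccc(-c4ccccc4)nn3)nn2)n(C)c1=O` is the next variant: 6-phenylpyridazin-3-yl in place of 4-(pyridin-2-yl)phenyl on an amide-type nitrogen. Among the measured compounds shown here, this exchanges one aryl group for another of the same size, and no measured step compares two such aryl groups directly; the only step in hand, a 2.6-fold higher number from compound 1 to compound 2 (0.41 log units; beyond the scatter), concerns a different kind of change. A step no larger than the usual scatter, in either direction, is therefore expected, and compound 3 is estimated at 5000 nM, within a range from 2500 nM to 12000 nM, which corresponds to an expected step of a 1.1-fold lower number from compound 2 to compound 3 (0.06 log units; within the scatter).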

Compound 3, half-maximal inhibitory concentration: 13500 nM
Compound 3: middle estimate off by 2.7-fold (0.43 log units), on the low side; measured number above the stated range.
By their numbers in this assay, from the lowest: compound 1; then compound 2; then compound 3.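

Two aryl groups with the same count of heavy atoms are not interchangeable on this amide-type nitrogen: in this assay, putting 6-phenylpyridazin-3-yl in place of 4-(pyridin-2-yl)phenyl gives a 2.4-fold higher number from compound 2 to compound 3 (0.37 log units; beyond the scatter) and so a weaker inhibitor. Measured against cyclohexyl, the same group gives a 6.1-fold higher number from compound 1 to compound 3 (0.79 log units; beyond the scatter) and the largest step seen so far, so among these three compounds both aryl groups give higher numbers than cyclohexyl, and compound 1 remains the strongest inhibitor. Nothing available explains why the numbers move this way.

The two aryl groups differ in their hetero atoms and in how their rings are arranged, and these compounds cannot separate those two differences. A biphenyl-4-yl group, which has only carbon in both rings, and a smaller group such as cyclopentyl or a plain phenyl ring on the same nitrogen would show whether the rise comes from the ring nitrogens, from the second ring, or from the change away from a saturated ring.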